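The compounds below may be only part of what the source reports. "The series", "measured", "known", "first", "only" and "open" are said of these compounds alone.

Measured in an ADME assay on BJ cells (Homo sapiens), read by MTT assay, with a stated time of 72 h; on this read-out higher numbers stand for weaker inhibition and lower numbers for stronger inhibition:
Compound 1 `COc1ncnc2c1c(-c1ccccc1)cn2[C@@H]1O[C@H](CO)[C@@H](O)[C@H]1O`: > 100000 nM, a limit of the assay and not a number
Compound 2 `COc1ncnc2c1c(-c1cc3ccccc3o1)cn2[C@@H]1O[C@H](CO)[C@@H](O)[C@H]1O`: 22400 nM

Within the data shown here, compound 2 holds the only true number so far. The other reading is a limit, and there is no spread of values to place compound 2 in. Compound 3 `C#Cc1cn([C@@H]2O[C@H](CO)[C@@H](O)[C@H]2O)c2ncnc(OC)c12` keeps the shared core and changes one group, with ethynyl in place of 1-benzofuran-2-yl on an aromatic carbon. Among the measured compounds shown here, one measured step bears on this change, made at the same place: an at least 4.4-fold lower number from compound 1 to compound 2 (0.64 log units; beyond the scatter), with 1-benzofuran-2-yl in place of phenyl. That step shows that the group here can move the number. However, it links two ring-bearing groups, whereas ethynyl has no ring, so it is a weak guide to direction. A shift of similar size either way seems possible, but the central expectation is no change beyond the scatter. The expected step is a 1.3-fold higher number from compound 2 to compound 3 (0.13 log units; within the scatter). Compound 3 could also read out only as a limit, as compound 1 did. For compound 3 the estimated value is 30000 nM, with an expected range from 4000 nM to 100000 nM.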

Compound 3, half-maximal inhibitory concentration: 98400 nM
The estimate for compound 3 lay 3.3-fold (0.52 log units) below the measured number; the range from low to high includes it.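

In this assay, the step from the ring-bearing 1-benzofuran-2-yl group to ethynyl, which has no ring, shows that this change on the aromatic carbon moves the number beyond the scatter: a 4.4-fold higher number from compound 2 to compound 3 (0.64 log units; beyond the scatter). Of the two groups here with a true number, 1-benzofuran-2-yl therefore gives the stronger inhibition, and the much smaller ethynyl group does not match it. The other step, an at least 1.0-fold lower number from compound 1 to compound 3 (0.00 log units; that floor lies within the scatter), starts from a limit of the assay and not a number, so it cannot place phenyl and ethynyl in order: the limit of > 100000 nM in this assay, at which 1 of the 3 values shown sits.

The compounds shown leave open which feature of 1-benzofuran-2-yl goes with the lower number, whether its second ring, its ring oxygen or its overall size, since the three groups at this place differ in several of these at once. A single furan-2-yl ring, an amine, a carboxylic acid or a longer chain on the same carbon would help to show how far the number follows the shape of the group and what kind of atoms it holds.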